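The source may report more compounds than this note shows. Statements on the series, on what has been measured and on what is new or still open speak of the compounds shown alone.

Working notes on the series, assessed in an assay for inhibition of Indoleamine 2,3-dioxygenase 1 (Homo sapiens), with stated times of 10 min and 60 min; on this read-out higher numbers stand for weaker inhibition and lower numbers for stronger inhibition. The measured compounds are compound 1 `FC(F)(F)c1cc(NCc2cccc3sccc23)c2cn[nH]c2c1`, compound 2 `O=C1NCc2c(NCc3ccccc3[N+](=O)[O-])cccc21` and compound 3 `O=[N+]([O-])c1cccc(CNc2cc(C(F)(F)F)cc3[nH]ncc23)c1`. In this assay compound 1 reaches only the limit of the assay, giving > 100000 nM. Compound 2 likewise returns only a limit, > 100000 nM. Compound 3 also sits at the limit, with > 100000 nM. None of the three results is a number. For the measured compounds named here, compound 3 therefore stands at the limit of > 100000 nM in this assay, at which 3 of the 3 values shown sit, and nothing among the measured compounds separates it from the other two. Going by the values given here, no step between measured compounds is available, so no measured effect of any single change is known in this assay.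

Compound 4 `OC1CCCC(Nc2cccc(CNc3cc(C(F)(F)F)cc4[nH]ncc34)c2)C1` differs from compound 3 in one place: (3-hydroxycyclohexyl)amino in place of nitro on an aromatic carbon. The recorded values give no direction for this change, and no comparison of nitro against (3-hydroxycyclohexyl)amino exists among the measured compounds. For compound 4 the expected step in this assay is an at least 2.0-fold lower number from compound 3 to compound 4 (0.30 log units; that floor lies within the scatter), which reflects no more than a guess that the value may move off the limit. The estimate for compound 4 is 50000 nM, within 5000 nM to 200000 nM, with a substantial chance that this assay again reports only a limit.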

Compound 4, half-maximal inhibitory concentration: > 100000 nM
Compound 4: only a limit was reported; the forecaster's own chance of this, stated with the estimate: 55%; middle value at least 2.0-fold (0.30 log units) away from the limit.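

In this assay compound 4 returns only a limit, > 100000 nM. Compound 3 is also recorded only as a limit, so no step can be read between compound 3 and compound 4 for (3-hydroxycyclohexyl)amino in place of nitro: the limit of > 100000 nM in this assay, at which 4 of the 4 values shown sit. The compounds shown leave open which structural change, if any, would give a value off this limit.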